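Clearance in the series: compound 3 and its ring replacement

A few compounds are considered here, and "the series" means these few. Any claim that something is new, unique, unknown or untested is made for them only; others in the source may bear on it.

Of the compounds shown here, three have been read in an in vitro ADME assay on microsomes from liver (Homo sapiens) for pharmacokinetics; on this read-out lower numbers stand for slow clearance and higher numbers for fast clearance. Compound 1 (`Cc1ccc(S(=O)(=O)N2C=CNC(=O)[C@H]2CC(=O)N[C@@H]2CCCc3cc(CN4CCCC4)ccc32)cc1`) reads < 50 mL.min-1.g-1, which is a limit of the assay. Compound 2 (`CCCN1CC[C@H](NC(=O)C[C@@H]2C(=O)NC=CN2S(=O)(=O)c2ccc(C)cc2)C(C)(C)C1`) reads < 50 mL.min-1.g-1, also a limit. Among the measured compounds shown here, compound 3 (`Cc1cc(S(=O)(=O)N2C=CNC(=O)[C@H]2CC(=O)N2CC[C@H](N3CCCC3)C2)c(C)cc1Cl`) gives 265 mL.min-1.g-1, the only true number so far.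

Compound 4 (`Cc1cc(S(=O)(=O)N2C=CNC(=O)[C@H]2CC(=O)N2CCCCC(N(C)C)CC2)c(C)cc1Cl`) departs from compound 3 on a carbonyl carbon: a group of 11 heavy atoms (9 carbon, 2 nitrogen; one eight-membered non-aromatic ring with 1 hetero atom) in place of a group of 10 heavy atoms (8 carbon, 2 nitrogen; 2 five-membered non-aromatic rings with 1 hetero atom each), on a carbonyl carbon. One eight-membered non-aromatic ring stands in place of 2 five-membered non-aromatic rings.

For the measured compounds named here, no measured step covers this change. Compound 3 at 265 mL.min-1.g-1 sits high against compound 1 and compound 2, so a moderate fall in this assay is expected. The expected step is a 1.7-fold lower number from compound 3 to compound 4 (0.22 log units; within the scatter). Compound 4 is estimated at 160 mL.min-1.g-1, with an expected range from 60 mL.min-1.g-1 to 420 mL.min-1.g-1.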

Compound 4, intrinsic clearance in microsomes: 60 mL.min-1.g-1
For compound 4 the middle estimate is 2.7-fold (0.43 log units) above the measured one; the range from low to high includes it.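

In this assay, the group on the carbonyl carbon clearly matters: one eight-membered non-aromatic ring in place of 2 five-membered non-aromatic rings gives a 4.4-fold lower number from compound 3 to compound 4 (0.65 log units; beyond the scatter). Among the compounds shown here, this is the first step that can be read, and it shows that clearance responds to a change at this position alone. The read-out has a limit, which a further fall from compound 4 could soon reach: the limit of < 50 mL.min-1.g-1 in this assay, at which 2 of the 4 values shown sit.

This single step cannot separate the effect of ring size from that of how the amine is attached. As far as these compounds go, how a primary amine on the eight-membered ring would read remains open.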